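Exchanging an amide for an ester on the shared core

This account rests on a few compounds, and the source may have more. Where it says the series, first, only, none or still open, it means among the compounds named here.

Measured so far:
Compound 1 `C#CCNC(=O)c1ccc(C(CC)(CC)c2ccc(OCC(=O)C(C)(C)C)c(C)c2)n1CC` gives 2200 nM.
Compound 2 `C#CCNC(=O)c1ccc(C(CC)(CC)c2ccc(OCC(O)C(C)(C)C)c(C)c2)n1CC` gives 240 nM.
Compound 3 `CCn1c(C(=O)Nc2ccc(OC(F)(F)F)cc2)ccc1C(CC)(CC)c1ccc(OCC(=O)C(C)(C)C)c(C)c1` reaches only a limit of the assay, > 50000 nM.

All three values come from an assay on HL-60 cells for agonist activity at vitamin D3 receptor (Homo sapiens), read by microscopy, with a stated time of 96 h; on this read-out lower numbers stand for an effect already at smaller amounts and higher numbers for an effect only at larger amounts of compound. Among the two numbers, compound 2 stands lowest; its nearest neighbour is compound 1, and the change between them reads a 9.2-fold lower number from compound 1 to compound 2 (0.96 log units; beyond the scatter), so compound 2 is the stronger agonist of the pair in this assay. The step towards the unmeasured compound 4 `CCn1c(C(=O)OCc2ccccn2)ccc1C(CC)(CC)c1ccc(OCC(O)C(C)(C)C)c(C)c1` keeps everything compound 2 has, apart from one exchange: (pyridin-2-yl)methoxy in place of propargylamino on a carbonyl carbon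

Going by the values given here, only one measured step touches this part of the core. From compound 1 to compound 3 a 4-(trifluoromethoxy)phenyl replaced propargyl on the amide-type nitrogen, and the result was an at least 22-fold higher number from compound 1 to compound 3 (1.35 log units; beyond the scatter), ending at the assay limit, (the limit of > 50000 nM in this assay, at which 1 of the 3 values shown sits). That change and the present one differ: there the nitrogen stayed and gained an aromatic group; here the propargylamino leaves altogether and an oxygen-linked aromatic group enters on the carbonyl carbon. Both, however, enlarge the same end of the molecule with an aromatic ring, so a rise in the number is expected, though plausibly less severe than for compound 3. The expected step is a 13-fold higher number from compound 2 to compound 4 (1.10 log units; beyond the scatter). Compound 4 is estimated at 3000 nM, with a likely range of 500 nM to 30000 nM.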

Compound 4, half-maximal effective concentration: > 50000 nM
Compound 4 gave a limit, no number; the forecaster's own chance of this, stated with the estimate: 20%; at least 16-fold (1.22 log units) between middle value and limit.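

In this assay, the exchange on the carbonyl carbon is a severe loss: an at least 200-fold higher number from compound 2 to compound 4 (2.31 log units; beyond the scatter). From the compounds shown here alone, the value of compound 4, > 50000 nM, is a limit of the assay and not a number, so the true size of this step stays unknown, and the compound joins compound 3 at that limit: the limit of > 50000 nM in this assay, at which 2 of the 4 values shown sit. The earlier large step began from the ketone, compound 1, and kept the amide-type nitrogen, whereas this one begins from the alcohol, compound 2, and has an oxygen on the carbonyl carbon, so the hydroxyl group that gave compound 2 the lower number of its pair does not preserve measurable activity once (pyridin-2-yl)methoxy enters.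

This single exchange removes the propargylamino group and its hydrogen-bond donor, changes the link to the carbonyl carbon from nitrogen to oxygen, and adds an aromatic ring, so the compounds shown cannot say which of these changes matters. A (pyridin-2-yl)methylamino amide would keep the nitrogen and the ring, while a propargyl ester would keep the propargyl chain and lose only the nitrogen, and these two groups could separate the effects.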